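The source may report more compounds than this note shows. Statements on the series, on what has been measured and on what is new or still open speak of the compounds shown alone.

Compound 1 `COc1ccc2nc(C)cc(OCC(=O)Nc3cc(C)cc(C)c3)c2c1` gives 26000 nM in a physicochemical assay for solubility, in phosphate buffer, measured as kinetic solubility, with a stated time of 1 h, at pH 7.4; on this read-out higher numbers stand for higher solubility and lower numbers for lower solubility.
Compound 2 `COc1ccc2nc(C)cc(OC(C)C(=O)Nc3cc(C)cc(C)c3)c2c1` gives 61000 nM in this assay.

Compound 2 stands highest of the two measured numbers in this assay, with compound 1 nearest. Compound 3 `COc1ccc2nc(C)cc(OC(C)(C)C(=O)Nc3cc(C)cc(C)c3)c2c1` differs from compound 2 by methyl in place of hydrogen on a saturated chain carbon bound to a carbonyl carbon, an oxygen on an aromatic ring and a saturated chain carbon. Among the compounds with values here, the only measured step that bears on this is the earlier one, a 2.3-fold higher number from compound 1 to compound 2 (0.37 log units; beyond the scatter), which adds the first methyl at the same saturated carbon. A second methyl there is expected to give a smaller step, a 1.3-fold higher number from compound 2 to compound 3 (0.12 log units; within the scatter). Compound 3 is therefore estimated at 80000 nM, within a range from 30000 nM to 200000 nM.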

Compound 3, solubility: 20000 nM
Compound 3: middle estimate off by 4.0-fold (0.60 log units), on the high side, and the stated range ends above it.
By their numbers in this assay, from the lowest: compounds 3 and 1 (each within the scatter of the next); then compound 2.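

In this assay, the second methyl on this saturated chain carbon gives a 3.1-fold lower number from compound 2 to compound 3 (0.48 log units; beyond the scatter), against a 2.3-fold higher number from compound 1 to compound 2 (0.37 log units; beyond the scatter) for the first, so the two changes at one carbon run in opposite directions. Compound 2, with one methyl, stands highest, while compound 3, with two, and compound 1, with none, lie within the scatter of each other. Nothing shown here gives a reason for this reversal. Going by these compounds, it remains open whether an ethyl group or a methoxy group at this carbon would follow compound 2 or compound 3.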